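Replacing the carboxylic acid of compound 2 with a pyrrolidine amide

The source may report more compounds than this note shows. Statements on the series, on what has been measured and on what is new or still open speak of the compounds shown alone.

Measured compounds:
- compound 1 `O=C(O)CSc1ccc(NCc2cccc(Oc3ccccc3)c2)cc1`: 84%
- compound 2 `CC(Cc1ccc(NCc2cccc(Oc3ccccc3)c2)cc1)C(=O)O`: 70%
- compound 3 `Cc1nc(-c2ccc(C(F)(F)F)cc2)sc1CNc1ccc(CC(C)C(=O)O)cc1`: 100%

In a functional assay on CHO cells for agonist activity at Free fatty acid receptor 1 (Homo sapiens), read by a luciferase reporter (a higher number here means a larger maximal response, a lower number a smaller maximal response), compound 2 gives 70%, the lowest of the three numbers. Compound 1 reaches 84%, and compound 3 reaches 100%. Going by the values given here, the only measured step, a number 14 percentage points lower from compound 1 to compound 2 (beyond the scatter), changes the acid-bearing chain but keeps a carboxylic acid in place.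

Compound 4 `O=C(CCc1ccc(NCc2cccc(Oc3ccccc3)c2)cc1)N1CCCC1` is not yet measured. Its difference from compound 2 is ((pyrrolidin-1-yl)carbonyl)methyl in place of 1-carboxyethyl on a saturated chain carbon bound to an aromatic carbon. Among the compounds with values here, all three measured compounds carry a carboxylic acid, so no measured step shows what happens when that acid is exchanged for an amide; the step from compound 1 to compound 2 shows only that a modest change of the acid chain moved the maximal response by a modest amount. The expectation for compound 4 is therefore uncertain and leans toward a smaller maximal response, with a number 35 percentage points lower from compound 2 to compound 4 (beyond the scatter) as the estimated step. Compound 4 is expected to give about 35%, within 5% to 70%.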

Compound 4, largest response reached (reported as percent of maximum), in percent of the reference or control that the assay uses: 46%
Beside the measured number, compound 4's estimate is 11 percentage points below it, within the range that was stated.
By their numbers in this assay, from the lowest: compound 4; then compound 2; then compound 1; then compound 3.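

Going by these compounds alone, compound 4 is the first compound here without a carboxylic acid, and in this assay exchanging that acid for a pyrrolidine amide brings a number 24 percentage points lower from compound 2 to compound 4 (beyond the scatter). The response is reduced but not lost, as compound 4 still gives 46%, so a carboxylic acid at this position is not strictly needed for agonist activity in this set. Measured against the thioether acid chain of compound 1, the gap is wider, with a number 38 percentage points lower from compound 1 to compound 4 (beyond the scatter), although that comparison changes the linking chain as well as the acid.

No measurement here explains why the response falls. The same change also removes the methyl branch, so carboxymethyl in place of 1-carboxyethyl, or a primary amide in place of the pyrrolidine amide, would be needed to separate the effects of the branch, the acid and the pyrrolidine ring.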